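Removing One Fluoro from Compound 1

The compounds below may be only part of what the source reports. "The series", "measured", "known", "first", "only" and "open" are said of these compounds alone.

- compound 1 `Cn1c(=O)c(S(=O)(=O)c2ccc(F)cc2F)cc2cnc(Nc3cccc4[nH]ccc34)nc21`: 1500 nM
- compound 2 `Cn1c(=O)c(S(=O)(=O)c2ccc(F)cc2F)cc2cnc(Nc3ccncn3)nc21`: 30000 nM
- compound 3 `Cc1cc2cc(Nc3ncc4cc(S(=O)(=O)c5ccc(F)cc5F)c(=O)n(C)c4n3)ccc2[nH]1`: 750 nM

All three values come from a functional assay on K562 cells (Homo sapiens) for inhibition, read by trypan blue exclusion, with a stated time of 72 h; a higher number here means a weaker inhibitor, a lower number a stronger inhibitor. Compound 1 sits within the scatter of compound 3, as a 2.0-fold lower number from compound 1 to compound 3 (0.30 log units; within the scatter) shows, while the gap to compound 2 is far wider, at a 20-fold higher number from compound 1 to compound 2 (1.30 log units; beyond the scatter). The next compound, compound 4 `Cn1c(=O)c(S(=O)(=O)c2ccc(F)cc2)cc2cnc(Nc3cccc4[nH]ccc34)nc21`, keeps everything in compound 1 except one substituent on the sulfonyl aryl ring: hydrogen in place of fluoro on an aromatic carbon. In other words, hydrogen takes the place of fluoro on an aromatic carbon, turning (2,4-difluorophenyl)sulfonyl into (4-fluorophenyl)sulfonyl.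

For the measured compounds named here, none of the measured steps touches this group. Each one exchanges the group on a nitrogen on an aromatic ring, whether a 20-fold higher number from compound 1 to compound 2 (1.30 log units; beyond the scatter), a 2.0-fold lower number from compound 1 to compound 3 (0.30 log units; within the scatter) or a 40-fold lower number from compound 2 to compound 3 (1.60 log units; beyond the scatter). The two large steps, both involving compound 2, show how much that other site can move the numbers, but they say nothing about the fluoro. The data therefore hold no direct measure of this change, and with so small an exchange, no shift in either direction can be argued from them. The expected outcome is no step beyond the scatter, and the estimated step is no change at the digits printed from compound 1 to compound 4 (within the scatter). For compound 4 the expected value is 1500 nM, with an estimated range from 500 nM to 4500 nM.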

Compound 4, half-maximal inhibitory concentration: 750 nM
For compound 4 the middle estimate is 2.0-fold (0.30 log units) above the measured one, within the range that was stated.
By their numbers in this assay, from the lowest: compounds 3, 4 and 1 (each within the scatter of the next); then compound 2.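

For the compounds shown here, the only reading at the sulfonyl aryl ring is in this assay and comes from hydrogen in place of fluoro on an aromatic carbon, ortho to a large group: a 2.0-fold lower number from compound 1 to compound 4 (0.30 log units; within the scatter). Unlike the exchanges on the nitrogen, where the step to the pyrimidin-4-yl compound is large (a 20-fold higher number from compound 1 to compound 2 (1.30 log units; beyond the scatter)), this one leaves the 2,4-difluorophenyl and 4-fluorophenyl forms indistinguishable in this read-out, so the fluoro at this place is not required to keep the number of compound 1. No data are available to explain this outcome.

As far as these compounds go, whether a methoxy group, an amine or a carboxylic acid on this aromatic carbon would also stay within the scatter remains open, as does the role of the fluoro that compound 4 keeps. Also open, from the compounds shown here alone, is whether hydrogen in place of fluoro would read the same with 2-methyl-1H-indol-5-yl on the nitrogen, as in compound 3, or with pyrimidin-4-yl, as in compound 2.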